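Amino in Place of Nitro in a Trimethoxyphenyl Amide Series

The source may hold more compounds than are shown below. What is called first, only, known or untested is meant among the compounds shown, and "the series" means these compounds.

Of the compounds shown here, three sharing one core have been tested in a functional assay on PC-3 cells (Homo sapiens) for antiproliferative activity, read by MTT assay, with a stated time of 48 h; on this read-out higher numbers stand for weaker inhibition and lower numbers for stronger inhibition. Compound 1, `COc1ccc(CN(C(=O)CSc2nc3ccccc3s2)c2cc(OC)c(OC)c(OC)c2)cc1[N+](=O)[O-]`, gives 26500 nM in this assay. Compound 2, `COc1ccc(CN(C(=O)CSc2nc3cc(Cl)ccc3s2)c2cc(OC)c(OC)c(OC)c2)cc1O`, gives 11200 nM, and compound 3, `COc1ccc(CN(C(=O)CSc2nc3c(C)cccc3s2)c2cc(OC)c(OC)c(OC)c2)cc1O`, gives 12300 nM. Compound 1 thus stands at the highest number of the three, beyond the scatter from both of the others, which means it is the weakest of these three at slowing cell growth.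

Compound 4, `COc1ccc(CN(C(=O)CSc2nc3ccccc3s2)c2cc(OC)c(OC)c(OC)c2)cc1N`, differs from compound 1 in one place: amino in place of nitro on an aromatic carbon. Going by the values given here, no measured pair isolates this exact change. Compounds 2 and 3 carry a hydroxyl where compound 1 carries a nitro, but each also differs from compound 1 at the group on sulfur, so their lower numbers cannot be attributed to one change alone. Among the compounds with values here, the only single-site step on record, a 1.1-fold higher number from compound 2 to compound 3 (0.04 log units; within the scatter), concerns that group on sulfur and shows no effect beyond the scatter, which makes it plausible that most of the gap between compound 1 and compounds 2 and 3 comes from the group exchanged on the aromatic carbon.

Compound 4 is therefore expected to show a modest improvement, a 1.8-fold lower number from compound 1 to compound 4 (0.25 log units; within the scatter). The estimate for compound 4 is 15000 nM, with a range from 6000 nM to 40000 nM.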

Compound 4, half-maximal inhibitory concentration: 7510 nM
Beside the measured number, compound 4's estimate is 2.0-fold (0.30 log units) above it; measured number inside the range.
By their numbers in this assay, from the lowest: compounds 4, 2 and 3 (each within the scatter of the next); then compound 1.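

In this assay, going by these compounds alone, the exchange of nitro for amino, with nothing else altered, gives a 3.5-fold lower number from compound 1 to compound 4 (0.55 log units; beyond the scatter) and so provides the first measured pair for a change at this position. The earlier compounds shown here could not show this, since compounds 2 and 3 differ from compound 1 in two places at once, whereas here the shift can be assigned to one group on an aromatic carbon, ortho to a methoxy group. No measured property of either group is available to account for the step, so its size is known but its cause is not.

Going by these compounds, a direct comparison of amino with hydroxyl on an identical core remains open, as does whether the gain from amino carries over when the group on sulfur is the 5-chloro or 4-methyl version found in compounds 2 and 3. On these data alone, it is also open how a methylamino group, an acetamide or a carboxylic acid at this position would compare with the amino group of compound 4.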